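This account rests on a few compounds, and the source may have more. Where it says the series, first, only, none or still open, it means among the compounds named here.

Measured compounds:
compound 1 `OC[C@H]1O[C@@H](n2cnc3c(NCc4cccc(Br)c4)ncnc32)[C@H](O)[C@@H]1O` with 19700 nM in a functional assay on K562 cells (Homo sapiens) for antiproliferative activity, with a stated time of 72 h; a higher number here means a weaker inhibitor, a lower number a stronger inhibitor
compound 2 `OC[C@H]1O[C@@H](n2cnc3c(NCc4ccc(Cl)c(Cl)c4)ncnc32)[C@H](O)[C@@H]1O` with 10800 nM in this assay

Compound 1 stands at the higher of the two numbers recorded in this assay; its nearest neighbour is compound 2, and the step of a 1.8-fold lower number from compound 1 to compound 2 (0.26 log units; within the scatter) lies within the scatter, so the two compounds cannot be ranked against each other on these data.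

The compound not yet measured is compound 3 `OC[C@H]1O[C@@H](n2cnc3c(NCc4ccc(C(F)(F)F)cc4)ncnc32)[C@H](O)[C@@H]1O`. It differs from compound 1 in one place: 4-(trifluoromethyl)phenyl in place of 3-bromophenyl on a saturated chain carbon bound to a nitrogen on an aromatic ring.

Among the compounds with values here, no measured step covers this change. Within the data shown here, the only step available, a 1.8-fold lower number from compound 1 to compound 2 (0.26 log units; within the scatter), exchanges one aryl group for another at the same place and stays within the scatter. That is thin ground, and it gives no direction. The expectation for compound 3 is therefore a step of a 1.3-fold lower number from compound 1 to compound 3 (0.12 log units; within the scatter) that does not go beyond the scatter, with a wide range to reflect the lack of a directly comparable pair. Compound 3 is estimated to give 15000 nM in this assay, between 5000 nM and 45000 nM.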

Compound 3, half-maximal inhibitory concentration: > 166000 nM
Compound 3 was reported as a limit (the forecaster's own chance of this, stated with the estimate: 15%); middle value at least 11-fold (1.04 log units) away from the limit.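

Compound 3 is reported only as a limit of the assay and not as a number: the limit of > 166000 nM in this assay, at which 1 of the 3 values shown sits.

Even so, the result shows that the aryl group on a saturated chain carbon bound to a nitrogen on an aromatic ring can matter in this assay: 4-(trifluoromethyl)phenyl gives an at least 8.4-fold higher number from compound 1 to compound 3 (0.92 log units; beyond the scatter), and against the other aryl group it gives an at least 15-fold higher number from compound 2 to compound 3 (1.18 log units; beyond the scatter). The earlier exchange, a 1.8-fold lower number from compound 1 to compound 2 (0.26 log units; within the scatter), had separated nothing, so compound 1 and compound 2 alone could not show that this place responds to the choice of aryl group.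

The compounds shown do not settle which feature of 4-(trifluoromethyl)phenyl goes with the step, since this group differs from both 3-bromophenyl and 3,4-dichlorophenyl in more than one respect. As far as these compounds go, how an unsubstituted phenyl, or a phenyl carrying a methoxy group, an amine or a carboxylic acid, would stand at this place remains open.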